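The source may report more compounds than this note shows. Statements on the series, on what has been measured and on what is new or still open speak of the compounds shown alone.

Compound 1 `Cc1ccccc1C(c1ccccc1)N1CCN(c2ncnc3c2cnn3-c2ccccc2)CC1` carries a 2-methylphenyl group on a saturated chain carbon bound to an amine nitrogen in a ring and an aromatic carbon. In a functional assay on cells (Rhabdomyosarcoma cell, Homo sapiens) for cytotoxicity (a higher number here means a weaker inhibitor, a lower number a stronger inhibitor), compound 1 gives > 25000 nM, which is a limit of the assay rather than a number. Going by the values given here, compound 2 `Cc1ccsc1C(c1c(C)noc1C)N1CCN(c2ncnc3c2cnn3-c2ccccc2)CC1` is the only other compound measured so far. In this assay compound 2 gives > 25000 nM, again a limit. Among the compounds with values here, compound 1 thus stands at the limit of > 25000 nM in this assay, at which 2 of the 2 values shown sit, and no step between measured compounds can be read. Compound 3 `Brc1ccc(C(c2ccccc2)N2CCN(c3ncnc4c3cnn4-c3ccccc3)CC2)cc1` differs from compound 1 by 4-bromophenyl in place of 2-methylphenyl on a saturated chain carbon bound to an amine nitrogen in a ring and an aromatic carbon. With both measured values sitting at the limit, the expected step that the limit leaves unreadable from compound 1 to compound 3 is none beyond the scatter. Compound 3 is therefore estimated to give about 30000 nM in this assay, within an expected range from 10000 nM to 100000 nM, the likeliest outcome being another limit.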

Compound 3, half-maximal inhibitory concentration: > 25000 nM
Compound 3: only a limit was reported (the forecaster's own chance of this, stated with the estimate: 80%); the middle value is on the limit's open side.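

Compound 3 also sits at a limit of the assay, > 25000 nM, so no step from compound 1 to compound 3 can be read, and all the values shown stand at the same limit: the limit of > 25000 nM in this assay, at which 3 of the 3 values shown sit.

What the compounds shown leave open is whether any change on this saturated chain carbon would bring a measurable value in this assay.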